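The compounds below may be only part of what the source reports. "The series", "measured", "known", "first", "only" and "open" are said of these compounds alone.

Of the compounds shown here, three of one shared core have been measured in a functional assay on NCI-H460 cells (Homo sapiens) for inhibition, read by MTT assay, with a stated time of 72 h; on this read-out higher numbers stand for weaker inhibition and lower numbers for stronger inhibition. Compound 1, `CN(C)CCn1c(=O)c(=Cc2ccc(F)cc2F)s/c1=C1\C(=O)Nc2cc(F)ccc21`, gives 3200 nM in this assay. Compound 2, `CCN(CC)CCCn1c(=O)c(=Cc2ccc(O)cc2)s/c1=C1\C(=O)Nc2ccc(C)cc21`, gives 260 nM in this assay. Compound 3, `CCN(CC)CCCn1c(=O)c(=Cc2ccccc2O)s/c1=C1\C(=O)Nc2ccc(Br)cc21`, gives 51700 nM in this assay. Among these three numbers compound 3 stands highest, that is, it is the weakest inhibitor of the set: the nearest of the others is compound 1, whose number is lower by more than the usual scatter, and the furthest is compound 2, whose number is lower by far more than the scatter.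

The next compound, compound 4, `CCN(CC)CCCn1c(=O)c(=Cc2ccccc2O)s/c1=C1\C(=O)Nc2ccc(C)cc21`, is compound 3 with one change: methyl in place of bromo on an aromatic carbon. For the measured compounds named here, no pair of measured compounds differs in this single place, so there is no measured step of this kind to lean on. Compound 2 carries a methyl at the same place and gives the lowest number of the three, but it differs from compound 3 in more than one place, so its value only hints at the direction. A moderate move toward stronger inhibition is therefore expected from compound 3 to compound 4, a 6.5-fold lower number from compound 3 to compound 4 (0.81 log units; beyond the scatter), with wide uncertainty. Compound 4 is estimated at 8000 nM in this assay, within a range from 1500 nM to 40000 nM.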

Compound 4, half-maximal inhibitory concentration: 11300 nM
Compound 4: the middle estimate sits 1.4-fold (0.15 log units) below what was measured, within the range that was stated.
By their numbers in this assay, from the lowest: compound 2; then compound 1; then compound 4; then compound 3.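

In this assay, the change from bromo to methyl on this aromatic carbon gives a 4.6-fold lower number from compound 3 to compound 4 (0.66 log units; beyond the scatter). For the compounds shown here, this is the first single-change reading at this place, and it shows that the number responds to the group held there, with the smaller value on the methyl side. The other single change, 2-hydroxyphenyl in place of 4-hydroxyphenyl, gives a 43-fold higher number from compound 2 to compound 4 (1.64 log units; beyond the scatter), a large step against the modest one from bromo to methyl, so with methyl fixed at the aromatic carbon, the place of the hydroxy group on the phenyl ring moves the number far more in this pair. No measurement here explains why either change has the effect it does.

As far as these compounds go, each step rests on a single pair, so it remains open whether the change from bromo to methyl would have the same size and direction in a compound carrying 4-hydroxyphenyl. The compounds shown also do not tell how a chlorine, a methoxy group or an amine on the same aromatic carbon would compare with bromo and methyl.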